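The source may hold more compounds than are shown below. What is called first, only, known or untested is meant among the compounds shown, and "the series" means these compounds.

Compound 1 `O=C(CCCCCCC(=O)Nc1cccc(F)c1)NO`: 1400 nM
Compound 2 `O=C(CCCCCCC(=O)Nc1ccc(Cl)cc1)NO`: 2100 nM

In a functional assay on HT-29 cells (Homo sapiens) for antiproliferative activity, with a stated time of 48 h (a higher number here means that more compound is needed for the effect, a lower number that less compound is needed), compound 2 gives 2100 nM and compound 1 gives 1400 nM. These two numbers lie within the usual scatter of each other, so compound 2 stands level with compound 1.

The next molecule is compound 3 `O=C(CCCCCCC(=O)Nc1ccc([N+](=O)[O-])cc1)NO`, which keeps the chain and hydroxamic end of compound 2 but has nitro in place of chloro on an aromatic carbon, para to a large group: nitro in place of chloro on an aromatic carbon. Among the measured compounds shown here, no measured pair differs in only one place, so the data give no direct guide to the size of this change. The only anchors are the two close values, so no step beyond the scatter is expected in this assay, and no direction is strongly favoured. The estimated 1.2-fold lower number from compound 2 to compound 3 (0.07 log units; within the scatter) is therefore small. For compound 3 the expected value is 1800 nM, with an estimated range of 800 nM to 4000 nM.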

Compound 3, half-maximal effective concentration: 76000 nM
Estimate against measurement, compound 3: 42-fold (1.63 log units) below; the whole stated range lies below it.
By their numbers in this assay, from the lowest: compounds 1 and 2 (each within the scatter of the next); then compound 3.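

In this assay, nitro in place of chloro on this aromatic carbon, para to a large group, gives a 36-fold higher number from compound 2 to compound 3 (1.56 log units; beyond the scatter) and so needs far more compound for the same effect. The earlier compounds shown here included no pair differing in only one place, so they could not show how much a single change here can matter. This position is therefore not indifferent to what it carries, at least in this one exchange, where one chlorine atom leaves and a group of one nitrogen and two oxygen atoms enters.

Nothing shown here explains the size of this step. From the compounds shown here alone, it also remains open whether the large step is specific to nitro, or whether an amine or a nitrile on the same carbon would give a value close to that of compound 2 or to that of compound 3.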